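This account rests on a few compounds, and the source may have more. Where it says the series, first, only, none or still open, it means among the compounds named here.

Measured compounds in the series so far:

Compound 1 `Cc1c(C(=O)CSCCO)[n+]([O-])c2ccccc2[n+]1[O-]` — in an ADME assay on Vero cells (Chlorocebus sabaeus) for cytotoxicity, read by MTT assay, with a stated time of 72 h (on this read-out lower numbers stand for higher toxicity in this test and higher numbers for lower toxicity in this test), compound 1 has "not determined" (no result reported).

Compound 2 `COc1ccc(C(=O)NCCSCC(=O)c2c(C)[n+]([O-])c3ccccc3[n+]2[O-])cc1` — in this assay compound 2 gives > 100 ug/mL.

Compound 2 therefore stands at a limit of the assay and not at a number: the limit of > 100 ug/mL in this assay, at which 1 of the 2 values shown sits. Going by the values given here, compound 1 contributes no figure at all, so no step between measured compounds can be read from these two entries, and nothing on the size of any change is yet known.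

Compound 3 `Cc1c(C(=O)CSCCNC(=O)c2ccncc2)[n+]([O-])c2ccccc2[n+]1[O-]` is the next member. Its difference from compound 2 is pyridin-4-yl in place of 4-methoxyphenyl on a carbonyl carbon, in short pyridin-4-yl in place of 4-methoxyphenyl on a carbonyl carbon; the rest of the molecule, including the shared core of compound 2, is kept.

With compound 2 showing only a limit, the expectation for this change is no step beyond the usual scatter: compound 3 is expected to sit near the same limit, with the step from compound 2 estimated as a step that the limit leaves unreadable from compound 2 to compound 3. The estimate for compound 3 in this assay is accordingly 120 ug/mL, with a range from 50 ug/mL to 300 ug/mL.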

Compound 3, half-maximal cytotoxic concentration: 50 ug/mL
Beside the measured number, compound 3's estimate is 2.4-fold (0.38 log units) above it, and the stated range covers the measured number.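

Compound 3 gives the series its first figure that is not a limit: in this assay, compound 3 gives 50 ug/mL with pyridin-4-yl on the carbonyl carbon whose other neighbour is the amide-type nitrogen. Pyridin-4-yl in place of 4-methoxyphenyl at this carbonyl carbon gives an at least 2.0-fold lower number from compound 2 to compound 3 (0.30 log units; that floor lies within the scatter), so the change is not shown to lie beyond the usual variation between repeated measurements, although a larger true step is not excluded. The figure is a floor and not a measured size, because compound 2 stands at a limit: the limit of > 100 ug/mL in this assay, at which 1 of the 3 values shown sits.

On these data alone, the true size of the step therefore remains open, and with it whether replacing 4-methoxyphenyl with pyridin-4-yl changes toxicity in this test at all. Going by these compounds alone, it also remains open how other groups on the same carbonyl carbon, such as unsubstituted phenyl, pyridin-3-yl or a short alkyl chain, would read in this assay when set against compound 3, the only compound here with a single number.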